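The source may report more compounds than this note shows. Statements on the series, on what has been measured and on what is new or still open speak of the compounds shown alone.

Compound 1 `COc1ccc2occ(CSC(=S)N3CCOCC3)c(=O)c2c1` and compound 2 `COc1ccc2occ(CSC(=S)N3CCCC3)c(=O)c2c1` share a core and differ only at the thiocarbonyl carbon. In a functional assay on SW480 cells (Homo sapiens) for antiproliferative activity, read by MTT assay, with a stated time of 72 h (a lower number here means a stronger inhibitor, a higher number a weaker inhibitor), compound 1 gives 7100 nM, and in this assay compound 2 gives 4800 nM. The change between them is morpholin-4-yl in place of pyrrolidin-1-yl on a thiocarbonyl carbon, and the step it made was a 1.5-fold higher number from compound 2 to compound 1 (0.17 log units; within the scatter). Compound 3 `O=c1c(Cl)c(CSC(=S)N2CCCC2)oc2ccccc12` is built on a different core; how that core differs from the core of compound 2 is not broken down here. In this assay compound 3 gives 1400 nM, the lowest of the three numbers, and its gaps to compound 2 and to compound 1 are both beyond the scatter. Compound 4 `O=c1c(Cl)c(CSC(=S)N2CCOCC2)oc2ccccc12` has not yet been measured. Among the measured compounds shown here, it differs from compound 3 by morpholin-4-yl in place of pyrrolidin-1-yl on a thiocarbonyl carbon, the same change as the one made from compound 2 to compound 1, at the same place. The expected step is of a similar modest size, a 1.4-fold higher number from compound 3 to compound 4 (0.15 log units; within the scatter), in view of a 1.5-fold higher number from compound 2 to compound 1 (0.17 log units; within the scatter). Compound 4 is therefore estimated to give 2000 nM in this assay, with a likely range from 900 nM to 4500 nM.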

Compound 4, half-maximal inhibitory concentration: 1800 nM
Beside the measured number, compound 4's estimate is 1.1-fold (0.05 log units) above it; low and high end bracket the measured number.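

In this assay, morpholin-4-yl in place of pyrrolidin-1-yl on a thiocarbonyl carbon gave a 1.3-fold higher number from compound 3 to compound 4 (0.11 log units; within the scatter). Set beside the same change on the other core, the new step shows that the change carried across the two cores with no difference that can be told apart: the same change on two cores in this assay, a 1.5-fold higher number (0.17 log units; within the scatter) from compound 2 to compound 1 and a 1.3-fold higher number (0.11 log units; within the scatter) from compound 3 to compound 4, 1.2-fold (0.06 log units) apart, within the scatter of two such steps Neither step stands clear of the scatter, so the pair shows no effect of this change in either direction, and two cores are too few to say how it would behave on any other core in the series.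

The compounds shown hold only two groups at the thiocarbonyl carbon, both of them saturated rings, so they leave open what a piperazine ring with a free amine or an open-chain diethylamino group would give there. They also leave open whether a larger step appears with such a group, and whether that step too would carry from one core to the other.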